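Amide aryl swaps and liver microsomal clearance

A few compounds are considered here, and "the series" means these few. Any claim that something is new, unique, unknown or untested is made for them only; others in the source may bear on it.

Measured compounds:
- compound 1 `CN1C[C@H](C(=O)Nc2ccc(Br)cc2)[C@@H](c2ccc(/C=C/C(=O)Nc3ccccc3N)cc2)C1`: 16 mL/min/kg
- compound 2 `CN1C[C@H](C(=O)Nc2ccccc2F)[C@@H](c2ccc(/C=C/C(=O)Nc3ccccc3N)cc2)C1`: 67 mL/min/kg
- compound 3 `Cc1cc(NC(=O)[C@H]2CN(C)C[C@@H]2c2ccc(/C=C/C(=O)Nc3ccccc3N)cc2)ccc1F`: 62 mL/min/kg

Notes. Three compounds sharing one core differ only in the aryl group on the amide-type nitrogen. In an in vitro ADME assay on microsomes from liver (Mus musculus) for pharmacokinetics, read by LC-MS, with a stated time of 10 min, tested at 1 uM (a higher number here means faster removal of the compound, a lower number slower removal), compound 1 gives 16 mL/min/kg, the lowest of the three numbers. The step of a 4.2-fold higher number from compound 1 to compound 2 (0.62 log units; beyond the scatter) and the step of a 3.9-fold higher number from compound 1 to compound 3 (0.59 log units; beyond the scatter) both lie beyond the scatter, while a 1.1-fold lower number from compound 2 to compound 3 (0.03 log units; within the scatter) is within it.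

The unmeasured compound 4 `CN1C[C@H](C(=O)Nc2ccc(Cl)cc2F)[C@@H](c2ccc(/C=C/C(=O)Nc3ccccc3N)cc2)C1` differs from compound 1 by 4-chloro-2-fluorophenyl in place of 4-bromophenyl on an amide-type nitrogen. The change keeps a halogen on the ring, as in compound 1, but adds a fluorine at the 2-position, as carried by compound 2. Among the compounds with values here, the two measured steps from compound 1 both gave modestly higher numbers in this assay; no measured pair isolates the effect of a halogen at the 4-position kept alongside the 2-fluorine. On that basis compound 4 is expected to sit between compound 1 and compound 2, with a step of a 2.2-fold higher number from compound 1 to compound 4 (0.34 log units; beyond the scatter) towards faster clearance that may or may not clear the scatter. The estimate for compound 4 in this assay is 35 mL/min/kg, with a range from 14 mL/min/kg to 85 mL/min/kg.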

Compound 4, clearance: 43 mL/min/kg
Compound 4: middle estimate off by 1.2-fold (0.09 log units), on the low side; low and high end bracket the measured number.
By their numbers in this assay, from the lowest: compound 1; then compounds 4, 3 and 2 (each within the scatter of the next).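

In this assay, a 1.6-fold lower number from compound 2 to compound 4 (0.19 log units; within the scatter) shows that chloro in place of hydrogen on an aromatic carbon, with the fluorine of the 4-chloro-2-fluorophenyl group kept, does not shift the number beyond the scatter. The halogen at the 4-position does not restore the low number of compound 1: a 2.7-fold higher number from compound 1 to compound 4 (0.43 log units; beyond the scatter), whereas a 1.4-fold lower number from compound 3 to compound 4 (0.16 log units; within the scatter), so compound 1 alone stands apart among the four compounds. Nothing at hand explains these steps.

As far as these compounds go, whether the low number of compound 1 goes with its bromine or with the lack of a fluorine stays open, since both change together in the step to compound 4. From the compounds shown here alone, how a nitrile, a methoxy group or an amine on this ring would compare also stays open.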